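Amide series: expectation for compound 4

This account rests on a few compounds, and the source may have more. Where it says the series, first, only, none or still open, it means among the compounds named here.

Of the compounds shown here, three have been measured in a functional assay on MCF7 cells (Homo sapiens) for cytotoxicity, read by MTT assay, with a stated time of 24 h, tested at 32 ug/mL; a lower number here means a weaker effect, a higher number a stronger effect of the compound at the concentration tested. Compound 1 `Cc1ccc2oc(SCC(=O)Nc3ccc(-c4nc(-c5ccccc5)c(-c5ccccc5)n4C)cc3)nc2c1` gives 57.7% and compound 2 `Cn1c(-c2ccc(NC(=O)CSc3nc4ccccc4s3)cc2)nc(-c2ccccc2)c1-c1ccccc1` gives 59%; the step between them is a number 1.3 percentage points higher from compound 1 to compound 2 (within the scatter). Compound 3 `CN(C)/C=C/N1CCN(CC(=O)Nc2ccc(-c3nc(-c4ccccc4)c(-c4ccccc4)n3C)cc2)CC1` gives 25.8%, the lowest of the three numbers, reached by the steps of a number 31.9 percentage points lower from compound 1 to compound 3 (beyond the scatter) and a number 33.2 percentage points lower from compound 2 to compound 3 (beyond the scatter). Compound 4 `Cn1c(-c2ccc(NC(=O)CN3CCN(Cc4ccc(Cl)cc4)CC3)cc2)nc(-c2ccccc2)c1-c1ccccc1` is not yet measured; it differs from compound 3 by 4-chlorobenzyl in place of 2-(dimethylamino)ethenyl on an amine nitrogen in a ring. Among the measured compounds shown here, no measured step touches this place: the two large steps exchange the whole group on the saturated chain carbon bound to the carbonyl carbon, and no measured compound carries a 4-chlorobenzyl. For the measured compounds named here, those steps show only that the compound bearing the six-membered non-aromatic ring with 2 nitrogen falls far below compounds 1 and 2, and the present change keeps that ring. The expected step is therefore small, a number 7.2 percentage points higher from compound 3 to compound 4 (within the scatter), with wide uncertainty. For compound 4 the estimate in this assay is 33%, expected to fall between 15% and 58%.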

Compound 4, a percentage reported as activity, at one concentration (the size of the read-out at that concentration, not a potency): 52.8%
The estimate for compound 4 lay 19.8 percentage points below the measured number; the measured number falls inside the stated range.
By their numbers in this assay, from the lowest: compound 3; then compounds 4, 1 and 2 (each within the scatter of the next).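

In this assay, the group on an amine nitrogen in a ring of the six-membered non-aromatic ring with 2 nitrogen proves to matter: with that ring kept, 4-chlorobenzyl in place of 2-(dimethylamino)ethenyl is a step of a number 27 percentage points higher from compound 3 to compound 4 (beyond the scatter). Among the compounds shown here, the low number of compound 3 therefore cannot be laid on that ring alone, a point the earlier steps could not settle, since they exchanged the whole group on the saturated chain carbon. Nothing measured on these compounds accounts for the size of this step.

A single pair leaves open whether the step belongs to the aromatic ring or to the chlorine. A plain benzyl, a 4-methoxybenzyl or a simple methyl on this nitrogen would help to separate the two.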